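Chain lengthening on two related cores and lipophilicity

The source may report more compounds than this note shows. Statements on the series, on what has been measured and on what is new or still open speak of the compounds shown alone.

Compound 1 `CCCc1ccc2[nH]c(-c3ccccc3)c(C3=C(Br)C(=O)NC3=O)c2c1` and compound 2 `CCCCc1ccc2[nH]c(-c3ccccc3)c(C3=C(Br)C(=O)NC3=O)c2c1` share one core and differ only in the chain: methyl in place of hydrogen on a saturated chain carbon, three bonds along the chain from an aromatic carbon. In a physicochemical assay for lipophilicity (on this read-out higher numbers stand for higher lipophilicity and lower numbers for lower lipophilicity), compound 1 gives 3.43 and compound 2 gives 3.74, so the change made a number 0.31 log units higher from compound 1 to compound 2 (beyond the scatter).

Compound 3 `CCc1cccc2c(C3=C(Br)C(=O)NC3=O)c(-c3ccc(OC)cc3)[nH]c12` is built on a second core; how that core differs from the core of compound 1 is not broken down here. In this assay compound 3 gives 3.35. Compound 3 and compound 1 stand within the scatter of each other, whereas compound 2 stands above compound 3 by a margin beyond the scatter.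

Compound 4 `CCCc1cccc2c(C3=C(Br)C(=O)NC3=O)c(-c3ccc(OC)cc3)[nH]c12` is not yet measured. It differs from compound 3 by methyl in place of hydrogen on a saturated chain carbon, two bonds along the chain from an aromatic carbon. Going by the values given here, this is the same kind of change as the one from compound 1 to compound 2, but not the same: in the earlier pair the new methyl sits three bonds along the chain from an aromatic carbon, here it sits two bonds along the chain from an aromatic carbon. Among the compounds with values here, the only guide is the step seen on the first core, and the step from compound 3 to compound 4 is expected to be a number 0.30 log units higher from compound 3 to compound 4 (within the scatter) because the earlier step read a number 0.31 log units higher from compound 1 to compound 2 (beyond the scatter). Compound 4 is therefore expected to give about 3.65 in this assay, most likely between 3.45 and 3.9.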

Compound 4, partition coefficient: 3.58
Compound 4: middle estimate off by 0.07 log units, on the high side, within the range that was stated.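

In this assay the new step is a number 0.23 log units higher from compound 3 to compound 4 (within the scatter) on the second core, and the earlier step is a number 0.31 log units higher from compound 1 to compound 2 (beyond the scatter) on the first core; the new step lies within the scatter and the earlier one beyond it, so compound 3 and compound 4 are not separated on this read-out. The result is compatible with the change carrying over from one core to the other, but it does not establish this: each core supplies a single pair, and the added methyl sits two bonds along the chain from an aromatic carbon in the new pair and three bonds along in the earlier one. No measurement bears on what lies behind either step.

Still open, on these data alone, is whether a longer chain on the core of compound 3 would build up to a step beyond the scatter, and whether the new step would hold with the methyl three bonds along the chain from an aromatic carbon. Also open, as far as these compounds go, is how a chain ending in an amine or a carboxylic acid would read in this assay on either core.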